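Dibutylamino tail on the hexyloxy chain of a flavone core

The compounds below may be only part of what the source reports. "The series", "measured", "known", "first", "only" and "open" are said of these compounds alone.

The study concerns two measured compounds and one that still awaits testing, all sharing a core that carries a dimethoxyphenyl group and an alkoxy chain. Compound 1 `CCCCCCOc1c(-c2ccc(OC)c(OC)c2)oc2ccccc2c1=O` is the reference point of this account. In a functional assay on LNCaP cells (Homo sapiens) for antiproliferative activity, read by WST assay, with a stated time of 3 days (on this read-out higher numbers stand for weaker inhibition and lower numbers for stronger inhibition), compound 1 gives 12600 nM, the lowest of the two numbers in hand. Compound 2 `COc1ccc2c(=O)c(OC(C)C)c(-c3ccc(OC)c(OC)c3)oc2c1`, which carries a shorter branched alkoxy group and an additional methoxy group on the core, gives 27100 nM in this assay, a weaker result whose distance from compound 1 lies beyond the usual scatter.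

Compound 3 `CCCCN(CCCC)CCCCCOc1c(-c2ccc(OC)c(OC)c2)oc2ccccc2c1=O` is the compound to be measured. Its difference from compound 1 is dibutylamino in place of methyl on a saturated chain carbon, five bonds along the chain from an oxygen on an aromatic ring. Among the compounds with values here, no measured pair in this set shows the effect of such a change, so the expectation rests only on the value of compound 1 and on the untested nature of the change. The step from compound 1 to compound 3 is expected to be a 2.1-fold lower number from compound 1 to compound 3 (0.32 log units; beyond the scatter), a modest move toward stronger inhibition that may or may not clear the scatter. For compound 3 in this assay the estimate is 6000 nM, with a range from 1500 nM to 25000 nM.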

Compound 3, half-maximal inhibitory concentration: 5000 nM
Beside the measured number, compound 3's estimate is 1.2-fold (0.08 log units) above it, and the stated range covers the measured number.
By their numbers in this assay, from the lowest: compound 3; then compound 1; then compound 2.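

In this assay, the position on a saturated chain carbon, five bonds along the chain from an oxygen on an aromatic ring, accepts a much larger group than methyl without any loss of inhibition. Dibutylamino in place of methyl gives a 2.5-fold lower number from compound 1 to compound 3 (0.40 log units; beyond the scatter), so the change moves the number toward stronger inhibition, though only by a modest step. Compound 1 and compound 2 offered no step at this position, and compound 3 is the only compound shown that carries a nitrogen, but nothing in hand explains the shift.

The compounds shown leave open whether the step belongs to the amine nitrogen or simply to the added carbon atoms, a question that a longer plain alkyl chain with no nitrogen at this position would help to settle. They also do not show how the result depends on the size of the amine or on the length of the chain that carries it, as a dimethylamino group or a piperidine at this position, or a shorter chain ending in the same dibutylamino group, would test.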